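The source may report more compounds than this note shows. Statements on the series, on what has been measured and on what is new or still open speak of the compounds shown alone.

Compound 1 `CCOC(=O)C1=C(C)NC(=O)NC1c1cn(C(=O)CNc2ccc([N+](=O)[O-])cc2C)c2ccccc12` gives 1.94 in a physicochemical assay for lipophilicity; a lower number here means a more polar compound, a higher number a more lipophilic compound. Compound 2 `CCOC(=O)C1=C(C)NC(=S)NC1c1cn(C(=O)CNc2ccc([N+](=O)[O-])cc2C)c2ccccc12` gives 3.34. Compound 3 `CCOC(=O)C1=C(C)NC(=O)NC1c1cn(C(=O)CNc2ccccc2[N+](=O)[O-])c2ccccc12` gives 1.48.

Compound 2 stands highest of the three in this assay; the difference between its core and that of compound 1 is not broken down here. Compound 1 and compound 3 share a core and differ by 2-nitrophenyl in place of 2-methyl-4-nitrophenyl on an amine nitrogen, a change that made the step of a number 0.46 log units lower from compound 1 to compound 3 (beyond the scatter).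

Compound 4 `CCOC(=O)C1=C(C)NC(=S)NC1c1cn(C(=O)CNc2ccccc2[N+](=O)[O-])c2ccccc12` has not yet been measured. It differs from compound 2 by 2-nitrophenyl in place of 2-methyl-4-nitrophenyl on an amine nitrogen, the same change seen between compound 1 and compound 3. Among the compounds with values here, compound 4 is therefore expected to sit below compound 2 by about a number 0.46 log units lower from compound 2 to compound 4 (beyond the scatter), resting on the single earlier step of a number 0.46 log units lower from compound 1 to compound 3 (beyond the scatter). Compound 4 is estimated at 2.88, with a plausible span from 2.45 to 3.3.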

Compound 4, partition coefficient: 2.88
Estimate against measurement, compound 4: no gap at the digits printed; low and high end bracket the measured number.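

In this assay, 2-nitrophenyl in place of 2-methyl-4-nitrophenyl on an amine nitrogen gives a number 0.46 log units lower from compound 2 to compound 4 (beyond the scatter) and, on the other core, a number 0.46 log units lower from compound 1 to compound 3 (beyond the scatter), so the change carried across with the same size at the digits printed. This rests on one pair of cores and a single change, and it does not show that the step would hold on any further core. Nothing available here bears on what sets the size of this step.

The compounds shown leave open how a plain phenyl on the amine nitrogen would compare. They also leave open whether the step keeps its size with a carboxylic acid in place of the ethyl ester.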